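The compounds below may be only part of what the source reports. "The series", "measured", "known", "first", "only" and "open" are said of these compounds alone.

Measured so far in a functional assay (QGY7701 cells, Homo sapiens) for inhibition, read by MTT assay, with a stated time of 48 h (on this read-out lower numbers stand for stronger inhibition and higher numbers for weaker inhibition), are two compounds:

- compound 1 `O=C(/C=C/c1coc2cc(O)ccc2c1=O)NCc1ccccc1` at 63000 nM
- compound 2 `COc1ccc2c(=O)c(/C=C/C(=O)NCc3ccc(C)cc3)coc2c1` at 10200 nM

Of these two numbers compound 2 has the lower, and its gap to compound 1 lies beyond the scatter. Compound 3 `Cc1ccc(CNC(=O)/C=C/c2coc3cc(O)ccc3c2=O)cc1` has not yet been measured. It departs from compound 2 by a single change hydrogen in place of methyl on an oxygen on an aromatic ring that reads as methoxy to hydroxy. Going by the values given here, no measured pair shows this change alone, so the expectation rests on thin ground. Among the compounds with values here, the one guide is that compound 1 also carries hydroxy at that place, and compound 1 stands at 63000 nM in this assay on the weak side of compound 2. A moderate step toward weaker inhibition is therefore expected in this assay, probably beyond the scatter, though none beyond it cannot be ruled out. The estimate amounts to an expected step of a 2.7-fold higher number from compound 2 to compound 3 (0.44 log units; beyond the scatter) on this read-out. For compound 3 the expected value is 28000 nM with an estimated range from 10000 nM to 70000 nM when the measurement is made.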

Compound 3, half-maximal inhibitory concentration: 24900 nM
For compound 3 the middle estimate is 1.1-fold (0.05 log units) above the measured one; the range from low to high includes it.
By their numbers in this assay, from the lowest: compound 2; then compound 3; then compound 1.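

In this assay, going by these compounds alone, the change from methoxy to hydroxy on the aromatic ring now stands alone for the first time: putting hydrogen in place of methyl on that oxygen gives a 2.4-fold higher number from compound 2 to compound 3 (0.39 log units; beyond the scatter), a modest weakening. Compound 3 also isolates the other difference between the earlier pair, since methyl in place of hydrogen on an aromatic carbon gives a 2.5-fold lower number from compound 1 to compound 3 (0.40 log units; beyond the scatter), so each of the two changes counts on its own, and in both a methyl goes with the lower number. No measurement shown bears on why either step arises.

The compounds shown leave open whether anything other than methyl or hydrogen on that oxygen, such as an ethyl group or a longer chain, would move the number further, and whether an amine in place of the hydroxy would behave like either of them. They also leave open whether the methyl on the aromatic carbon gives a step of similar size when methoxy rather than hydroxy is present, and whether a chlorine at that place would do the same.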